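The compounds below may be only part of what the source reports. "The series", "measured", "known", "first", "only" and "open" are said of these compounds alone.

In an assay on RBL-1 cells with Polyunsaturated fatty acid 5-lipoxygenase (Rattus norvegicus) as the target (a higher number here means a weaker inhibitor, a lower number a stronger inhibitor), three compounds have been measured so far. Compound 1 `CC(C)(C)c1ccc2ccccc2c1O` gives 180 nM. Compound 2 `Cc1ccc(Cc2ccc3ccccc3c2O)cc1` gives 24 nM. Compound 3 `COc1ccc2ccc(Cc3ccccc3)c(O)c2c1` gives 3500 nM. Compound 2 therefore has the lowest number of the three, that is, the strongest inhibition. Its nearest neighbour is compound 1, whose number is higher by a margin beyond the usual scatter of repeated measurements, and compound 3 lies furthest away, with a number higher by a much wider margin. Within the data shown here, none of these three compounds differs from another in only one place, so no single clean step between measured compounds can be read off; what follows rests on the structures alone.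

Compound 4 `CSc1ccc(Cc2ccc3ccccc3c2O)cc1` has not yet been measured in this assay. It differs from compound 2 in one place: methylsulfanyl in place of methyl on an aromatic carbon. Among the measured compounds shown here, no measured pair in this set shows what such an exchange does, so the expectation is cautious. The step of a 1.3-fold higher number from compound 2 to compound 4 (0.10 log units; within the scatter) is expected to be small, at most a little beyond the scatter, in either direction. For compound 4 the expected value in this assay is 30 nM, with a range from 10 nM to 90 nM.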

Compound 4, half-maximal inhibitory concentration: 48 nM
The estimate for compound 4 lay 1.6-fold (0.20 log units) below the measured number; the measured number falls inside the stated range.
By their numbers in this assay, from the lowest: compounds 2 and 4 (each within the scatter of the next); then compound 1; then compound 3.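

In this assay the exchange of methyl for methylsulfanyl on an aromatic carbon, para to a large group, gives a 2.0-fold higher number from compound 2 to compound 4 (0.30 log units; within the scatter), so the two compounds cannot be told apart by this read-out. Among these compounds, this is the first step in the set that changes only one place, and so the first direct reading of this position: methylsulfanyl, with 2 heavy atoms against 1 for methyl and 1 hydrogen-bond acceptor against 0, leaves the number within the scatter. No measurement shown here speaks to why the two numbers stay this close.

From the compounds shown here alone, one exchange says little about how broadly this position accepts change, so it remains open whether a carboxylic acid, an amine or a longer chain such as butyl in the same place would also leave the number within the scatter. Going by these compounds, it is equally open whether methylsulfanyl in place of methyl would give so small a step on a different core, such as that of compound 3.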